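Notes on a pyridinyl swap at the core

A few compounds are considered here, and "the series" means these few. Any claim that something is new, unique, unknown or untested is made for them only; others in the source may bear on it.

Compound 1 `O=C(/C=C/c1cn(-c2ccccc2)nc1-c1ccsc1)c1ccccc1`: in a functional assay on Huh-7 cells (Homo sapiens) for inhibition, read by sulforhodamine B assay, with a stated time of 72 h (a higher number here means a weaker inhibitor, a lower number a stronger inhibitor), compound 1 gives 4700 nM
Compound 2 `COc1ccc(C(=O)/C=C/c2cn(-c3ccccc3)nc2-c2ccsc2)cc1OC`: compound 2 gives 2900 nM
Compound 3 `COc1ccc(OC)c(C(=O)/C=C/c2cn(-c3ccccc3)nc2-c2ccsc2)c1`: compound 3 gives 2100 nM

Compound 1 stands at the highest of the three numbers. The nearest is compound 2, a 1.6-fold lower number from compound 1 to compound 2 (0.21 log units; within the scatter), and the furthest compound 3, a 2.2-fold lower number from compound 1 to compound 3 (0.35 log units; beyond the scatter). Between the two dimethoxy analogues, a 1.4-fold lower number from compound 2 to compound 3 (0.14 log units; within the scatter). Every measured step changes only the aryl group on the carbonyl carbon; the core of compound 1 itself is left as it is in all three.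

Compound 4 `O=C(/C=C/c1cn(-c2ccccc2)nc1-c1ccncc1)c1ccccc1` goes elsewhere: pyridin-4-yl in place of thiophen-3-yl on an aromatic carbon. Within the data shown here, none of the measured steps touches this position, so no measured step bears directly on the change. What the series does show is that varying a ring at the other end of the molecule moved the number by modest amounts at most, which is weak support for expecting a modest outcome here as well. The working expectation for compound 4 is therefore no step beyond the scatter from compound 1, a 1.1-fold higher number from compound 1 to compound 4 (0.03 log units; within the scatter), with the range set wide for want of precedent. Compound 4 is estimated at 5000 nM, expected to fall between 2000 nM and 12000 nM.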

Compound 4, half-maximal inhibitory concentration: 1800 nM
For compound 4 the middle estimate is 2.8-fold (0.44 log units) above the measured one; measured number outside the range, below it.
By their numbers in this assay, from the lowest: compounds 4, 3, 2 and 1 (each within the scatter of the next, the first and the last beyond it).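

Among these compounds, the place on the core bearing thiophen-3-yl responds to a single ring change: in this assay, the swap gives a 2.6-fold lower number from compound 1 to compound 4 (0.42 log units; beyond the scatter), whereas the earlier compounds varied only the aryl group on the carbonyl carbon and left this place untested. The step is modest, but it shows that this place need not be held as thiophen-3-yl, and that pyridin-4-yl is accepted here without any loss in this assay. The two groups share the same hydrogen-bond donor and acceptor counts and carry no net charge, differing in ring size and in the hetero atom, and nothing measured here separates those differences or explains the lower number.

Open, on these data alone, is whether the ring size or the ring nitrogen carries the step, a question that phenyl, pyridin-3-yl or furan-3-yl at this place could help to settle, and whether a ring bearing an amine or a carboxylic acid is tolerated here. Also open, as far as these compounds go, is whether the step holds when pyridin-4-yl is paired with 2,5-dimethoxyphenyl or 3,4-dimethoxyphenyl on the carbonyl carbon.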